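Methylphenyl Position in a Series at the Limit

The source may report more compounds than this note shows. Statements on the series, on what has been measured and on what is new or still open speak of the compounds shown alone.

Compound 1, `CN1C[C@@H]2CN(c3ccc(-c4ccccc4)cc3)C[C@@H]2C1`, in an assay on membranes from brain for displacement of a labelled ligand from Neuronal acetylcholine receptor; alpha4/beta2 (Rattus norvegicus) (on this read-out lower numbers stand for stronger inhibition and higher numbers for weaker inhibition), gives > 100000 nM.
Compound 2, `Cc1ccc(-c2ccc(N3C[C@H]4CN(C)C[C@H]4C3)nn2)cc1`, in this assay gives > 100000 nM.
Compound 3, `Cc1cccc(-c2ccc(N3C[C@H]4CN(C)C[C@H]4C3)nn2)c1`, in this assay gives > 100000 nM.

Each of these three values is a limit of the assay rather than a number. For compound 1 the value is a limit. For compound 2 the value is a limit. For compound 3 the value is a limit as well, so its standing can only be described as sitting at that limit, together with the other two, which is summed up in the limit of > 100000 nM in this assay, at which 3 of the 3 values shown sit. Within the data shown here, the only step between measured compounds that differ in one place is a step that the two limits leave unreadable from compound 2 to compound 3, a swap of the methyl on the phenyl, and the two limits leave its size unreadable.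

Compound 4 is `Cc1ccccc1-c1ccc(N2C[C@H]3CN(C)C[C@H]3C2)nn1`. It differs from compound 3 by 2-methylphenyl in place of 3-methylphenyl on an aromatic carbon. Among the measured compounds shown here, this is the same kind of change as the one from compound 2 to compound 3, and that step gave no readable size. For the measured compounds named here, with compound 3 at a limit of > 100000 nM and no measured step showing any gain, the expectation for compound 4 in this assay is that it stays at or beyond the limit; the estimated step is a step that the limit leaves unreadable from compound 3 to compound 4. Compound 4 is therefore estimated at 200000 nM, with a range from 50000 nM to 1000000 nM.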

Compound 4, inhibition constant: > 10000 nM
Compound 4: a limit, no number; the forecaster's own chance of this, stated with the estimate: 85%; the middle value lies beyond the limit too.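

In this assay compound 4 gives > 10000 nM, which is a limit and not a number. The steps linking compound 2, compound 3 and compound 4 all join limits, and none of them can be read. The compounds shown leave open whether moving the methyl around the phenyl changes binding at all.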